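A few compounds are considered here, and "the series" means these few. Any claim that something is new, unique, unknown or untested is made for them only; others in the source may bear on it.

Measured compounds in a functional assay on NCI-H460 cells (Homo sapiens) for cytotoxicity, read by MTT assay, with a stated time of 72 h; a higher number here means a weaker inhibitor, a lower number a stronger inhibitor:
Compound 1 `CCN(CC)Cc1ccc2nc(NC(=O)N/N=C/c3cn(Cc4ccccc4Cl)c4ccccc34)sc2c1` gives 980 nM
Compound 2 `CCN(CC)Cc1ccc2nc(NC(=O)N/N=C/c3cn(Cc4ccc(C)cc4)c4ccccc34)sc2c1` gives 320 nM
Compound 3 `CCN(CC)Cc1ccc2nc(NC(=O)N/N=C/c3cn(Cc4ccc(Cl)cc4Cl)c4ccccc34)sc2c1` gives 1080 nM

Compound 3 carries the highest of the three numbers, but its separation from compound 1 is a 1.1-fold higher number from compound 1 to compound 3 (0.04 log units; within the scatter), so the two cannot be ordered; only compound 2 stands apart, by a 3.4-fold higher number from compound 2 to compound 3 (0.53 log units; beyond the scatter). Compound 4 `CCN(CC)Cc1ccc2nc(NC(=O)N/N=C/c3cn(Cc4ccc(Cl)c(Cl)c4)c4ccccc34)sc2c1` is built from compound 3 by 3,4-dichlorophenyl in place of 2,4-dichlorophenyl on a saturated chain carbon bound to an aromatic nitrogen. Going by the values given here, no measured step rearranges the two chlorines on this ring, so none bears directly on it. The nearest comparison is a 1.1-fold higher number from compound 1 to compound 3 (0.04 log units; within the scatter), which adds the second chlorine to the ring and leaves the number where it was; the larger shifts, a 3.1-fold lower number from compound 1 to compound 2 (0.49 log units; beyond the scatter) and a 3.4-fold higher number from compound 2 to compound 3 (0.53 log units; beyond the scatter), both involve the 4-methylphenyl compound 2 and do not inform a chloro rearrangement. Compound 4 is therefore expected to sit near compound 3, with a step of a 1.2-fold lower number from compound 3 to compound 4 (0.08 log units; within the scatter) that is not expected to exceed the scatter. The estimate for compound 4 is 900 nM, within a range of 400 nM to 2200 nM.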

Compound 4, half-maximal inhibitory concentration: 610 nM
Compound 4: middle estimate off by 1.5-fold (0.17 log units), on the high side; the measured number falls inside the stated range.
By their numbers in this assay, from the lowest: compounds 2, 4, 1 and 3 (each within the scatter of the next, the first and the last beyond it).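

In this assay, going by these compounds alone, moving a chlorine from 2,4-dichlorophenyl to 3,4-dichlorophenyl on a saturated chain carbon bound to an aromatic nitrogen gives the first direct reading of a rearrangement at this position, with the same atoms joined differently: a 1.8-fold lower number from compound 3 to compound 4 (0.25 log units; within the scatter) and no order between the two isomers. The other two steps, a 1.9-fold higher number from compound 2 to compound 4 (0.28 log units; within the scatter) and a 1.6-fold lower number from compound 1 to compound 4 (0.21 log units; within the scatter) as well, show that compound 4 cannot be separated from any of the three earlier compounds, even though compound 2 and compound 3 stand apart from each other. Nothing available offers a reason for these numbers.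

The compounds shown leave open how this position responds to other ring groups, such as methoxy or trifluoromethyl. They also leave open whether a pyridine ring could take the place of the phenyl ring.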